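A few compounds are considered here, and "the series" means these few. Any claim that something is new, unique, unknown or untested is made for them only; others in the source may bear on it.

Measured in a functional assay on SMMC-7721 cells (Homo sapiens) for antiproliferative activity, read by MTT assay, with a stated time of 48 h; on this read-out higher numbers stand for weaker inhibition and lower numbers for stronger inhibition:
- compound 1 `CC(C)=CCC[C@]1(C)/C=C/[C@@H](OC(=O)C=C(C)C)[C@](C)(O)/C=C/C(=O)/C(CCl)=C\C1`: 840 nM
- compound 2 `CC(C)=CCC[C@]1(C)/C=C/[C@@H](OC(=O)C=C(C)C)[C@](C)(O)/C=C/C(=O)/C(COC(=O)c2ccc([N+](=O)[O-])cc2)=C\C1`: 2560 nM

Compound 2, at 2560 nM, has the higher of the two numbers in this assay, so it is the weaker inhibitor. Compound 3 `CC(C)=CCC[C@]1(C)/C=C/[C@@H](OC(=O)C=C(C)C)[C@](C)(O)/C=C/C(=O)/C(CN=[N+]=[N-])=C\C1` carries azido in place of ((4-nitrophenyl)carbonyl)oxy on a saturated chain carbon bound to a double-bonded ring carbon. Within the data shown here, the only measured guide is a modest step, a 3.0-fold higher number from compound 1 to compound 2 (0.48 log units; beyond the scatter). Azido has no ring, like the chloro of compound 1, so a move back toward lower numbers is expected, of similar or smaller size. The expected change is a 2.1-fold lower number from compound 2 to compound 3 (0.33 log units; beyond the scatter). For compound 3 the estimated value is 1200 nM, with a range of 450 nM to 3200 nM.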

Compound 3, half-maximal inhibitory concentration: 3080 nM
Beside the measured number, compound 3's estimate is 2.6-fold (0.41 log units) below it, and the stated range covers the measured number.
By their numbers in this assay, from the lowest: compound 1; then compounds 2 and 3 (each within the scatter of the next).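

In this assay, azido in place of ((4-nitrophenyl)carbonyl)oxy gives a 1.2-fold higher number from compound 2 to compound 3 (0.08 log units; within the scatter) and so no real difference, even though the group entering has far fewer heavy atoms than the one leaving. Losing the ring is also not enough to match chloro, since azido in place of chloro gives a 3.7-fold higher number from compound 1 to compound 3 (0.56 log units; beyond the scatter) at this same carbon. No evidence here explains these results. Going by these compounds, whether an amine, a carboxylic acid or a longer chain on this carbon would reach the number of compound 1 stays open.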